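The source may hold more compounds than are shown below. What is called first, only, known or untested is meant among the compounds shown, and "the series" means these compounds.

Working notes on the benzofuran-free description: the shared core of compound 1 `CC(C)NC(=N)c1ccc2cc(-c3ccc(OCCCOc4ccccc4)cc3)oc2c1` carries an isopropylamidine and a three-carbon-linked phenoxy chain; compound 2 `N=C(N)c1ccc2cc(-c3ccc(OCCCCCCOc4ccccc4)cc3)oc2c1` carries the unsubstituted amidine and a six-carbon linker. In an ADME assay on L6 cells (Rattus norvegicus) for cytotoxicity, read by resazurin assay, with a stated time of 70 h (on this read-out lower numbers stand for stronger inhibition and higher numbers for weaker inhibition), compound 1 gives 49900 nM, while compound 2 gives 8000 nM, the lowest of the two numbers and beyond the scatter from compound 1. Compound 3 `CC(C)NC(=N)c1ccc2cc(-c3ccc(OCCCCCCOc4ccccc4)cc3)oc2c1` is compound 2 with isopropyl in place of hydrogen on an amine nitrogen; compound 1 and compound 2 differ in two places, so their gap is not read as a single step. Going by the values given here, no measured step isolates this change. A move in this assay toward a higher number is expected for compound 3, of moderate size, a 2.5-fold higher number from compound 2 to compound 3 (0.40 log units; beyond the scatter), given that compound 1, which also carries the isopropyl group, stands at 49900 nM. Compound 3 is therefore estimated at 20000 nM, with a range from 6000 nM to 60000 nM.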

Compound 3, half-maximal inhibitory concentration: 4900 nM
Compound 3: middle estimate off by 4.1-fold (0.61 log units), on the high side, outside the stated range (below it).
By their numbers in this assay, from the lowest: compounds 3 and 2 (each within the scatter of the next); then compound 1.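

In this assay, the amino to isopropylamino change on the amine nitrogen gives a 1.6-fold lower number from compound 2 to compound 3 (0.21 log units; within the scatter), so with this chain in place the isopropyl group does not separate the pair. By contrast, 3-phenoxypropyl in place of phenoxy on a saturated chain carbon, with isopropyl present in both compounds, gives a 10-fold lower number from compound 1 to compound 3 (1.01 log units; beyond the scatter), which places the large step in this set at the chain and not at the amine nitrogen. No measurement here offers a reason for either step.

As far as these compounds go, it remains open whether isopropyl in place of hydrogen would also stay within the scatter on the shorter chain of compound 1. From the compounds shown here alone, how a longer chain, or a cyclopentyl group on the amine nitrogen, would read in this assay also remains open.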